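Methyl on the Ring Amine: Two Cores Compared

The source may hold more compounds than are shown below. What is called first, only, known or untested is meant among the compounds shown, and "the series" means these compounds.

Measured compounds:
compound 1, `O=S(=O)(c1cccc(F)c1)c1cn(C2CCNC2)c2ncccc12` – 278 nM
compound 2, `CN1CCC(n2cc(S(=O)(=O)c3cccc(F)c3)c3cccnc32)C1` – 231 nM
compound 3, `O=S(=O)(C1=C(Cl)NC2SC=CN12)c1cn(C2CCCNC2)c2ncccc12` – 66 nM

The study concerns three compounds measured in a functional assay on HeLa cells for agonist activity at 5-hydroxytryptamine receptor 6 (Homo sapiens), read by cAMP accumulation and immunoassay (on this read-out lower numbers stand for an effect already at smaller amounts and higher numbers for an effect only at larger amounts of compound), and one more awaiting measurement. In this assay compound 1 gives 278 nM and compound 2 gives 231 nM. The two differ by methyl in place of hydrogen on an amine nitrogen in a ring, and the step is a 1.2-fold lower number from compound 1 to compound 2 (0.08 log units; within the scatter). Compound 3 gives 66 nM, the lowest of the three numbers; how its core differs from the core of compound 1 is not broken down here.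

Compound 4, `CN1CCCC(n2cc(S(=O)(=O)C3=C(Cl)NC4SC=CN34)c3cccnc32)C1`, has not yet been measured. It differs from compound 3 by methyl in place of hydrogen on an amine nitrogen in a ring. This is the same kind of change as that from compound 1 to compound 2, though the place differs: in the earlier pair the amine nitrogen sits in a five-membered non-aromatic ring with 1 nitrogen, here in a six-membered non-aromatic ring with 1 nitrogen, in both cases two ring bonds from the ring atom that bears a large group.

Because the earlier step was a 1.2-fold lower number from compound 1 to compound 2 (0.08 log units; within the scatter), the expectation for compound 4 is a step of about the same small size, a 1.1-fold lower number from compound 3 to compound 4 (0.06 log units; within the scatter), with no firm direction claimed. Compound 4 is therefore estimated at 58 nM in this assay, with a range from 25 nM to 135 nM expected.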

Compound 4, half-maximal effective concentration: 25 nM
For compound 4 the middle estimate is 2.3-fold (0.37 log units) above the measured one; the measured number falls inside the stated range.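

In this assay, methyl in place of hydrogen on the ring amine gives a 2.6-fold lower number from compound 3 to compound 4 (0.42 log units; beyond the scatter), a step that stands beyond the usual scatter on this core, whereas the same change on the core of compound 1 does not. Set side by side, however, the two steps cannot be told apart: the same change on two cores in this assay, a 1.2-fold lower number (0.08 log units; within the scatter) from compound 1 to compound 2 and a 2.6-fold lower number (0.42 log units; beyond the scatter) from compound 3 to compound 4, 2.2-fold (0.34 log units) apart, within the scatter of two such steps. In neither pair does methyl go with a higher number beyond the scatter, so the change carries from one core to the other without contradiction, but this does not show that the core sets the size of the step, and with a single pair per core, each with an amine ring of a different size, the influence of the core cannot be separated from that of the ring.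

The compounds shown leave open whether an ethyl or an acetyl group on the same amine nitrogen would behave as methyl does. They also leave open whether the step seen on the core of compound 3 would recur with the five-membered ring of compound 1 in place of the six-membered ring, or whether the six-membered ring would give such a step on the core of compound 1.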